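A few compounds are considered here, and "the series" means these few. Any claim that something is new, unique, unknown or untested is made for them only; others in the source may bear on it.

Measured so far in a functional assay on U-87MG ATCC cells (Homo sapiens) for inhibition; on this read-out lower numbers stand for stronger inhibition and higher numbers for weaker inhibition:
- compound 1 `COc1cc(/C=C/C(=O)c2cccc(NC(=O)c3c(Cl)cccc3Cl)c2)ccc1O`: 17.8 ug/mL
- compound 2 `COc1cc(/C=C/C(=O)c2cccc(NC(=O)c3cccs3)c2)ccc1O`: 14.7 ug/mL
- compound 3 `COc1cc(/C=C/C(=O)c2cccc(N)c2)ccc1O`: 7.71 ug/mL

Compound 3 stands at 7.71 ug/mL, clearly apart from compound 1 but not from compound 2, whose gap to it stays within the scatter. Compound 4 `COc1cc(/C=C/C(=O)c2cccc(NC(=O)C(C)C)c2)ccc1O` has isopropylcarbonyl in place of hydrogen on a nitrogen on an aromatic ring, a change that counts as isopropylcarbonyl in place of hydrogen on a nitrogen on an aromatic ring.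

Two measured steps run the opposite way, taking a carbonyl-linked group off that nitrogen: a 2.3-fold lower number from compound 1 to compound 3 (0.36 log units; beyond the scatter), and a 1.9-fold lower number from compound 2 to compound 3 (0.28 log units; within the scatter). Exchanging one such group for the other mattered little: a 1.2-fold lower number from compound 1 to compound 2 (0.08 log units; within the scatter). Within the data shown here, no measured compound carries a group without a ring at this nitrogen, so the new group remains untested. Adding it is therefore expected to raise the number by about the size of those two steps, close to the edge of the scatter. The expected change is a 1.8-fold higher number from compound 3 to compound 4 (0.26 log units; within the scatter). The estimated value for compound 4 is 14 ug/mL, with an expected range of 7.5 ug/mL to 25 ug/mL.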

Compound 4, half-maximal inhibitory concentration: 8.31 ug/mL
Compound 4: middle estimate off by 1.7-fold (0.23 log units), on the high side, within the range that was stated.
By their numbers in this assay, from the lowest: compounds 3, 4, 2 and 1 (each within the scatter of the next, the first and the last beyond it).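

In this assay, isopropylcarbonyl on the nitrogen gives a 1.1-fold higher number from compound 3 to compound 4 (0.03 log units; within the scatter), so this amide stays within the scatter of the free amine. The group on the carbonyl carbon now shows a split: isopropyl in place of thiophen-2-yl gives a 1.8-fold lower number from compound 2 to compound 4 (0.25 log units; within the scatter), still within the scatter, while isopropyl in place of 2,6-dichlorophenyl gives a 2.1-fold lower number from compound 1 to compound 4 (0.33 log units; beyond the scatter), which goes beyond it. Compound 4 carries a carbonyl on this nitrogen, as compound 1 does. Compound 4 remains within the scatter of compound 3, while compound 1 does not.

The data offer no measured explanation for this split. On these data alone, it remains open whether an acetyl group, a longer chain such as n-butyl, or a chain ending in a carboxylic acid on that carbonyl carbon would also stay within the scatter of compound 3.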